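The compounds below may be only part of what the source reports. "The series", "measured", "known", "first", "only" and "open" are said of these compounds alone.

Half-life in an ADME assay on a cell-free system (plasma, Homo sapiens) for metabolic stability, with Plasma (Rattus norvegicus) as the target, read by HPLC, at pH 7.4 (on this read-out higher numbers stand for a longer-lived compound and lower numbers for a shorter-lived compound), measured so far:
Compound 1 `CC(=O)Oc1ccccc1C(=O)O[C@H]1CO[C@H]2[C@@H]1OC[C@H]2OC(=O)c1ccccc1O`: 0.0825 h
Compound 2 `CC(=O)Oc1ccccc1C(=O)O[C@H]1CO[C@H]2[C@@H]1OC[C@H]2OC(=O)c1cccc(O)c1`: 0.0183 h
Compound 3 `CC(=O)Oc1ccccc1C(=O)O[C@H]1CO[C@H]2[C@@H]1OC[C@H]2OC(=O)c1ccc(C#N)cc1`: 0.0888 h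

Compound 2 holds the lowest number of the three in this assay, and both other compounds lie beyond the scatter from it: a 4.5-fold lower number from compound 1 to compound 2 (0.65 log units; beyond the scatter), and a 4.9-fold higher number from compound 2 to compound 3 (0.69 log units; beyond the scatter). The two compounds that carry a group other than 3-hydroxyphenyl on the carbonyl carbon sit together within the scatter, a 1.1-fold higher number from compound 1 to compound 3 (0.03 log units; within the scatter).

Compound 4 `CC(=O)Oc1ccccc1C(=O)O[C@H]1CO[C@H]2[C@@H]1OC[C@H]2OC(=O)c1ccncc1` is not yet measured. Its change from compound 2 is pyridin-4-yl in place of 3-hydroxyphenyl on a carbonyl carbon. The leaving group brings one hydrogen-bond donor and one acceptor, the entering group no donor and one acceptor.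

The step that bears most directly on it is the other replacement of 3-hydroxyphenyl in compound 2, a 4.9-fold higher number from compound 2 to compound 3 (0.69 log units; beyond the scatter), a modest rise beyond the scatter. Going by the values given here, the shared core with a 2-hydroxyphenyl or a 4-cyanophenyl ester gives much the same number, so the low value of compound 2 is tied to its 3-hydroxyphenyl alone; no step with pyridin-4-yl exists in this set. A rise of that order in this assay is therefore expected from compound 2 to compound 4, a 3.8-fold higher number from compound 2 to compound 4 (0.58 log units; beyond the scatter). Compound 4 is estimated at 0.07 h, in a range from 0.03 h to 0.15 h.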

Compound 4, half-life: 0.0617 h
Estimate against measurement, compound 4: 1.1-fold (0.05 log units) above; the range from low to high includes it.
By their numbers in this assay, from the lowest: compound 2; then compounds 4, 1 and 3 (each within the scatter of the next).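

In this assay, pyridin-4-yl on the carbonyl carbon gives a clear separation from the 3-hydroxyphenyl ester, with a 3.4-fold higher number from compound 2 to compound 4 (0.53 log units; beyond the scatter), so a ring with a hetero atom and no hydrogen-bond donor also leaves the low number of compound 2 behind. The new ester cannot be told apart from the other two, with a 1.4-fold lower number from compound 3 to compound 4 (0.16 log units; within the scatter) and a 1.3-fold lower number from compound 1 to compound 4 (0.13 log units; within the scatter), so among these four compounds pyridin-4-yl, 2-hydroxyphenyl and 4-cyanophenyl read alike at this position and only 3-hydroxyphenyl stands apart. No measurement at hand accounts for the low number of compound 2 or for the likeness of the other three.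

As far as these compounds go, it remains open whether the low number belongs to the hydroxyl group or to its place on the ring, which a 4-hydroxyphenyl, 3-methoxyphenyl or 3-aminophenyl ester would help to settle. Also open, from the compounds shown here alone, is how the half-life responds to a saturated ring such as piperidin-4-yl, or to a carboxylic acid on the aromatic ring.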